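Hydroxy to methoxy: an estimate for compound 3

A few compounds are considered here, and "the series" means these few. Any claim that something is new, unique, unknown or untested is made for them only; others in the source may bear on it.

In an ADME assay on MT4 cells (Homo sapiens) for cytotoxicity, read by MTT assay, with a stated time of 4 days (a lower number here means that less compound is tolerated, a higher number that more compound is tolerated), compound 1 `CC(=O)Nc1ccc2oc(-c3ccccc3)c(O)c(=O)c2c1` gives 64700 nM and compound 2 `CC(=O)Nc1ccc2oc(-c3ccc(C(F)(F)F)cc3)c(O)c(=O)c2c1` gives 7300 nM. Compound 2 thus holds the lower of the two numbers, which makes it the less tolerated of this pair. Compound 3 `COc1c(-c2ccc(C(F)(F)F)cc2)oc2ccc(NC(C)=O)cc2c1=O` differs from compound 2 at one place: methyl in place of hydrogen on an oxygen on an aromatic ring. Put simply, this is hydroxy to methoxy, with methyl in place of hydrogen on an oxygen on an aromatic ring.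

Among the compounds with values here, only one measured step is available, an 8.9-fold lower number from compound 1 to compound 2 (0.95 log units; beyond the scatter). That step put trifluoromethyl in place of hydrogen on an aromatic carbon, which is a different change at a different place. Within the data shown here, it cannot give the direction here, and no measured pair tests the hydroxy group itself. Among the measured compounds shown here, it shows only that a single change to the shared core can move the number modestly. A smaller step is therefore expected, leaning weakly towards a higher number and possibly staying within the scatter. The expected step is a 1.5-fold higher number from compound 2 to compound 3 (0.18 log units; within the scatter). For compound 3 the estimated value is 11000 nM, with an expected range from 3000 nM to 40000 nM.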

Compound 3, half-maximal cytotoxic concentration: 332000 nM
For compound 3 the middle estimate is 30-fold (1.48 log units) below the measured one; the whole stated range lies below it.
By their numbers in this assay, from the lowest: compound 2; then compound 1; then compound 3.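

In this assay, within the data shown here, turning the hydroxy group into methoxy gives a 45-fold higher number from compound 2 to compound 3 (1.66 log units; beyond the scatter) and so shows that this oxygen is a sensitive place on the shared core, something no earlier pair could test. The change is small on paper, with one methyl of a single heavy atom replacing a hydrogen, yet its step is classed as large, whereas the earlier trifluoromethyl change, an 8.9-fold lower number from compound 1 to compound 2 (0.95 log units; beyond the scatter) in the same assay, is classed as modest. The two steps also run in opposite directions: trifluoromethyl on the aromatic carbon brought the number down, while methyl on the oxygen raises it well past the scatter, so more of compound 3 is tolerated than of compound 2.

The compounds shown leave open whether a longer chain such as ethoxy, or an amine in place of the hydroxy group, would behave like methoxy, and whether the same change on compound 1, which lacks the trifluoromethyl group, would give a step of similar size. Nothing shown here offers a measured explanation for the size of this step.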